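This account rests on a few compounds, and the source may have more. Where it says the series, first, only, none or still open, it means among the compounds named here.

Working notes on the series. Of the compounds shown here, two of this set have been measured in a functional assay on the whole organism (artery, strain albino) with Rattus norvegicus as the target, with a stated time of 360 min, at a dose of 10 mg/kg by the oral route; on this read-out higher numbers stand for more inhibition at the one dose given (going by the name of the read-out) and lower numbers for less inhibition. Compound 1, `CC1=C(C(=O)Nc2ccc(Br)cc2)C(c2ccc(Cl)cc2Cl)N=C(SCc2ccc(F)cc2)N1`, gives 40.7%. Compound 2, `COc1ccc(C2N=C(SCc3cccc(Cl)c3)NC(C)=C2C(=O)Nc2ccc(Br)cc2)cc1`, gives 39.7%. Compound 2 thus stands at the lower of the two numbers, but its distance to compound 1 lies within the scatter, so the two values cannot be put in order and the inhibition in this assay cannot be called higher or lower for either compound on this read-out.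

Compound 3, `COc1ccc(C2N=C(SCc3ccc(F)cc3)NC(C)=C2C(=O)Nc2ccc(Br)cc2)cc1`, has not yet been measured in this assay. Against compound 2 it differs in one place: 4-fluorophenyl in place of 3-chlorophenyl on a saturated chain carbon bound to a sulfur. For the measured compounds named here, no pair of measured compounds differs by this change alone, so there is no measured step of this kind to lean on; the only guide is the pair of values at hand, which sit close together.

With that, a step of no size beyond the scatter is expected, in either direction. The expected step is a number 0.3 percentage points higher from compound 2 to compound 3 (within the scatter). Compound 3 is estimated at 40% in this assay, with a range from 25% to 55%.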

Compound 3, a percentage reported as inhibition, in the whole organism at one dose (the size of the read-out at that dose, not a potency): 33.5%
For compound 3 the middle estimate is 6.5 percentage points above the measured one, within the range that was stated.
By their numbers in this assay, from the lowest: compounds 3, 2 and 1 (each within the scatter of the next).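

For the compounds shown here, the step of a number 6.2 percentage points lower from compound 2 to compound 3 (within the scatter) gives the first one-place reading in this assay for the group on a saturated chain carbon bound to a sulfur, and it shows that 4-fluorophenyl in place of 3-chlorophenyl does not separate the two compounds on this read-out. The step of a number 7.2 percentage points lower from compound 1 to compound 3 (within the scatter) gives the same kind of reading for a second place, a saturated ring carbon, where 4-methoxyphenyl in place of 2,4-dichlorophenyl also leaves the two compounds inseparable at the one dose given. No measured property of these groups bears on either step, so the numbers stand without an explanation.

From the compounds shown here alone, each of the two places has been read only once, for a single pair of aryl groups, so it remains open whether either step would keep its size with a different group at the other place. Going by these compounds, it also remains open whether anything other than a substituted phenyl, such as an amine or a carboxylic acid carried on a longer chain in place of the 4-fluorobenzyl, would give a step beyond the scatter.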